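Indole vinyl sulfone series: removing the ring methoxy

A few compounds are considered here, and "the series" means these few. Any claim that something is new, unique, unknown or untested is made for them only; others in the source may bear on it.

Measured compounds:
compound 1 `COc1ccc(-c2[nH]c3ccccc3c2/C=C(\C#N)S(=O)(=O)c2ccccc2)cc1` — 578 nM
compound 2 `O=C(/C(=C\c1c(-c2ccccc2)[nH]c2ccccc12)S(=O)(=O)c1ccccc1)c1ccccc1` — 6600 nM
compound 3 `COc1ccc2[nH]c(-c3ccccc3)c(/C=C(\C#N)S(=O)(=O)c3ccccc3)c2c1` — 8300 nM

In a functional assay on OVCAR-4 cells (Homo sapiens) for inhibition, read by sulforhodamine B assay, with a stated time of 48 h (on this read-out lower numbers stand for stronger inhibition of growth and higher numbers for weaker inhibition of growth), compound 3 gives 8300 nM, the highest of the three numbers; compound 2 sits within the scatter of it, while compound 1 lies clearly below it. Compound 4 `N#C/C(=C\c1c(-c2ccccc2)[nH]c2ccccc12)S(=O)(=O)c1ccccc1` differs from compound 3 by hydrogen in place of methoxy on an aromatic carbon. Among the measured compounds shown here, no measured pair isolates this change, so its size is open. Compound 1, which also lacks this methoxy, gives 578 nM, which leaves room for a number below that of compound 3, though compound 1 differs from compound 4 elsewhere as well. A moderate step toward a lower number is expected, a 3.3-fold lower number from compound 3 to compound 4 (0.52 log units; beyond the scatter). Compound 4 is estimated at 2500 nM, within 600 nM to 9000 nM.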

Compound 4, concentration for 50% growth inhibition: 5500 nM
Estimate against measurement, compound 4: 2.2-fold (0.34 log units) below; the measured number falls inside the stated range.
By their numbers in this assay, from the lowest: compound 1; then compounds 4, 2 and 3 (each within the scatter of the next).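

In this assay the methoxy on the six-membered aromatic ring of the fused system carries little weight, with a 1.5-fold lower number from compound 3 to compound 4 (0.18 log units; within the scatter) and a similar reading for cyano in place of benzoyl in a 1.2-fold lower number from compound 2 to compound 4 (0.08 log units; within the scatter). The same hydrogen-for-methoxy change on the aromatic carbon of compound 1 counts for far more, giving a 9.5-fold higher number from compound 1 to compound 4 (0.98 log units; beyond the scatter). Nothing measured here explains this contrast. On these data alone, whether an amine or a hydroxyl at either aromatic carbon would behave like methoxy or like hydrogen stays open, as does a longer alkoxy chain at the site in compound 1.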